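This account rests on a few compounds, and the source may have more. Where it says the series, first, only, none or still open, it means among the compounds named here.

Working notes on the series. Compound 1 `O=C1c2ccccc2C(=O)N1c1ccc(S)cc1`, compound 2 `Cc1ccc2c(c1)C(=O)N(c1ccc([N+](=O)[O-])cn1)C2=O` and compound 3 `Nc1ccc(CN2C(=O)c3ccccc3C2=O)cc1` have been run in a functional assay on HL-60 cells (Homo sapiens) for cytotoxicity, read by MTT assay, with a stated time of 24 h; a higher number here means a weaker inhibitor, a lower number a stronger inhibitor. Compound 1 reaches only the limit of this assay, > 200000 nM. Compound 2 likewise gives a limit and not a number, > 200000 nM. For compound 3 this assay again reports only a limit, > 200000 nM. Going by the values given here, all three measured values sit at the same limit (the limit of > 200000 nM in this assay, at which 3 of the 3 values shown sit), so no step between measured compounds that differ in one place can be read. Compound 4 `Cc1cccc2c1C(=O)N(Cc1ccc(N)cc1)C2=O` is not yet measured; it differs from compound 3 by methyl in place of hydrogen on an aromatic carbon. With every measured compound at the limit, no direction of change is supported by the data. The step from compound 3 to compound 4 is expected to be a step that the limit leaves unreadable from compound 3 to compound 4, within the scatter. Compound 4 is estimated at 300000 nM, with a range from 100000 nM to 1000000 nM, most likely reported again as a limit.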

Compound 4, half-maximal inhibitory concentration: > 200000 nM
Compound 4: no number, only a limit; the forecaster's own chance of this, stated with the estimate: 85%; the middle value is on the limit's open side.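

No step can be read from compound 3 to compound 4, as both values are limits: the limit of > 200000 nM in this assay, at which 4 of the 4 values shown sit.

Left open is whether any compound shown gives a number in this assay and what methyl in place of hydrogen on an aromatic carbon changes there.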